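The compounds below may be only part of what the source reports. "The series", "measured", "known", "first", "only" and "open" are said of these compounds alone.

Of the compounds shown here, two have been measured so far in a functional assay on MCF7 cells (Homo sapiens) for cytotoxicity, read by MTT assay, with a stated time of 48 h; on this read-out higher numbers stand for weaker inhibition and lower numbers for stronger inhibition. Compound 1, with the structure `CNC(=O)CSc1nc2ccc(NC(=O)c3ccccc3)cc2s1`, gives 34400 nM in this assay. Compound 2, with the structure `CC(=O)Nc1ccc2nc(SCC(=O)NCc3ccc(Cl)cc3)sc2c1`, gives 10200 nM in this assay. Of these two numbers, compound 2 has the lower one, and compound 1 stands a good way higher, a gap that lies beyond the usual scatter of this kind of measurement. For the measured compounds named here, no single-point step between the two measured compounds is available, since they differ from one another in more than one place.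

Compound 3, with the structure `CNC(=O)CSc1nc2ccc(NC(C)=O)cc2s1`, has not yet been measured. Compared with compound 2, it carries hydrogen in place of 4-chlorophenyl on a saturated chain carbon bound to an amide-type nitrogen. Starting from compound 2, this removes a sizeable ring-bearing group and leaves only the shorter chain. Going by the values given here, with no measured step of this kind to lean on, the expectation is that compound 3 will show a moderate move toward weaker inhibition, a step of a 3.9-fold higher number from compound 2 to compound 3 (0.59 log units; beyond the scatter) in this assay, though a result within the scatter of compound 2 cannot be ruled out. Compound 3 is accordingly estimated at 40000 nM in this assay, with a likely range from 15000 nM to 110000 nM.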

Compound 3, half-maximal inhibitory concentration: > 100000 nM
Compound 3 ended at the assay's limit; the forecaster's own chance of this, stated with the estimate: 25%; middle value at least 2.5-fold (0.39 log units) away from the limit.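

Compound 3 reads as a limit of this assay and not as a number: (the limit of > 100000 nM in this assay, at which 1 of the 3 values shown sits). For the compounds shown here, on a saturated chain carbon bound to an amide-type nitrogen, hydrogen in place of 4-chlorophenyl, which is the same as going from 4-chlorobenzyl to methyl, gives an at least 9.8-fold higher number from compound 2 to compound 3 (0.99 log units; beyond the scatter) and shows for the first time that this one change alone carries a clear loss on this read-out, something compound 1 and compound 2 could not show, since they differ in more than one place. A second single change, methyl in place of phenyl on a carbonyl carbon, gives an at least 2.9-fold higher number from compound 1 to compound 3 (0.46 log units; beyond the scatter) so in these two steps, the only ones available, losing a ring-bearing group goes with weaker inhibition each time.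

Both steps are only lower bounds, so their true sizes remain unknown and the compounds shown cannot say which of the two changes costs more. On these data alone, it also remains open whether the 4-chlorophenyl ring itself matters or whether length alone would serve, a question that a plain benzyl group without chlorine or a longer chain such as butyl in the same place would help to separate.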